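The source may hold more compounds than are shown below. What is called first, only, known or untested is meant among the compounds shown, and "the series" means these compounds.

Working notes on the diaryl borinic acid series.

Compound 1 `COc1ccccc1B(O)c1ccccc1OC` gives in an assay on HEK293 cells for inhibition of transient receptor potential cation channel subfamily V member 6 (Homo sapiens), read by FLIPR and calcium flux, with a stated time of 5 min (on this read-out lower numbers stand for stronger inhibition and higher numbers for weaker inhibition), only a limit, > 500000 nM, with no number behind it (the limit of > 500000 nM in this assay, at which 1 of the 3 values shown sits). Compound 2 `OB(c1ccc(C(F)(F)F)cc1)c1ccc(C(F)(F)F)cc1`, with a trifluoromethyl on each ring, gives 10800 nM in this assay. Compound 3 `OB(c1ccccc1)c1ccc(Cl)cc1`, carrying a single chloro, gives 9700 nM in this assay; this value and that of compound 2 lie within the usual scatter of each other, so neither compound can be set apart from the other on the numbers available.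

Compound 4 `OB(c1ccccc1)c1ccc(C(F)(F)F)cc1` has not yet been measured. It differs from compound 3 by trifluoromethyl in place of chloro on an aromatic carbon. Among the compounds with values here, no measured pair in the set differs in exactly this way, so the size of the step cannot be read off directly. Within the data shown here, the only guide is that compound 2, with two trifluoromethyls, sits at 10800 nM, close to compound 3. On that basis compound 4 is expected to stay near compound 3, with a step from compound 3 to compound 4 of a 1.0-fold higher number from compound 3 to compound 4 (0.01 log units; within the scatter), not beyond the scatter in either direction. The estimate for compound 4 in this assay is 10000 nM, with a range of 4000 nM to 25000 nM.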

Compound 4, half-maximal inhibitory concentration: 11300 nM
Compound 4: the middle estimate sits 1.1-fold (0.05 log units) below what was measured, within the range that was stated.
By their numbers in this assay, from the lowest: compounds 3, 2 and 4 (each within the scatter of the next). At a limit, above all of these: compound 1.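

Trifluoromethyl in place of chloro on this aromatic carbon gives, in this assay, a 1.2-fold higher number from compound 3 to compound 4 (0.07 log units; within the scatter), so the first direct comparison at this position does not set the two groups apart. Hydrogen in place of trifluoromethyl on an aromatic carbon gives a 1.0-fold higher number from compound 2 to compound 4 (0.02 log units; within the scatter), so the second trifluoromethyl of compound 2 also produces no separation from compound 4. Within the data shown here, both one-place comparisons therefore stay inside the scatter, whereas the earlier compounds offered no pair differing in only one place.

Going by these compounds, whether an amine or a carboxylic acid on this aromatic carbon would stay within the same scatter remains open, since both groups compared here are halogen-bearing or halogen itself. Nothing measured here bears on why these steps are so small.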